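A few compounds are considered here, and "the series" means these few. Any claim that something is new, unique, unknown or untested is made for them only; others in the source may bear on it.

Of the compounds shown here, three have so far been measured in a functional assay on NCI-H358 cells (Homo sapiens) for cytotoxicity, read by sulforhodamine B assay; a higher number here means that more compound is needed for the effect, a lower number that less compound is needed. Compound 1 `CCCCCCCCCCCCCC[C@@H](O)[C@@H](O)[C@H](CO)n1cc(CCCC)nn1` gives 12900 nM, compound 2 `CCCCCCCCCCCCCC[C@@H](O)[C@@H](O)[C@H](CO)n1cc(CCCCCC)nn1` gives 13700 nM, and compound 3 `CCCCCCCCCCCCC/C=C/[C@@H](O)[C@H](CO)n1cc(CCCCCC)nn1` gives 12800 nM. Compound 1 differs from compound 2 by hydrogen in place of ethyl on a saturated chain carbon, four bonds along the chain from an aromatic carbon, a change that produced a 1.1-fold lower number from compound 2 to compound 1 (0.03 log units; within the scatter). The difference between the core of compound 3 and the core of compound 2 is not broken down here. Compound 4 `CCCCCCCCCCCCC/C=C/[C@@H](O)[C@H](CO)n1cc(CCCC)nn1` has not yet been measured; it differs from compound 3 by hydrogen in place of ethyl on a saturated chain carbon, four bonds along the chain from an aromatic carbon, the same change at the same place. Because the earlier step was a 1.1-fold lower number from compound 2 to compound 1 (0.03 log units; within the scatter), a similarly small step is expected here: a 1.1-fold lower number from compound 3 to compound 4 (0.03 log units; within the scatter). Compound 4 is therefore estimated at 12000 nM, with a likely range from 6000 nM to 24000 nM.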

Compound 4, half-maximal effective concentration: 13600 nM
The estimate for compound 4 lay 1.1-fold (0.05 log units) below the measured number; low and high end bracket the measured number.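

In this assay replacing ethyl with hydrogen on a saturated chain carbon, four bonds along the chain from an aromatic carbon, gives a 1.1-fold higher number from compound 3 to compound 4 (0.03 log units; within the scatter) and so no readable change. Set beside the earlier step, the change behaves alike on both cores, with neither step standing out from the noise: the same change on two cores in this assay, a 1.1-fold lower number (0.03 log units; within the scatter) from compound 2 to compound 1 and a 1.1-fold higher number (0.03 log units; within the scatter) from compound 3 to compound 4, 1.1-fold (0.05 log units) apart, within the scatter of two such steps. This shows that the lack of effect carries over between these two cores, but it does not show that a change with a real effect would carry over as well, and the two steps give no direction. The compounds shown leave open whether a much longer chain, or a chain carrying an amine or a carboxylic acid, would move the number beyond the scatter.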